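The compounds below may be only part of what the source reports. "The series", "measured", "known", "first", "only" and "open" are said of these compounds alone.

Of the compounds shown here, three built on one shared core have been measured for cytotoxicity. Compound 1 `OC(c1ccc(Cl)cc1)(c1ccc(Br)cc1)c1cccnc1` carries a bromo group, compound 2 `OC(c1ccc(Cl)cc1)(c1ccc(C(F)(F)F)cc1)c1cccnc1` a trifluoromethyl group in its place, and compound 3 `OC(c1ccc(Cl)cc1)(c1cccnc1)c1ccccc1Br` keeps the bromo group but joins the same atoms differently. In an ADME assay on L6 cells (Rattus norvegicus) for cytotoxicity, read by resazurin assay, with a stated time of 72 h (on this read-out higher numbers stand for weaker inhibition and lower numbers for stronger inhibition), compound 1 gives 57000 nM. Compound 2 gives 56400 nM in this assay, and compound 3 gives 55200 nM in this assay.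

The change from compound 1 to compound 2 is trifluoromethyl in place of bromo on an aromatic carbon and produced a 1.0-fold lower number from compound 1 to compound 2 (0.00 log units; within the scatter). The two cores differ as described by 2-bromophenyl in place of 4-bromophenyl on a saturated chain carbon bound to two aromatic carbons and an oxygen on a saturated carbon, with a 1.0-fold lower number from compound 1 to compound 3 (0.01 log units; within the scatter).

Compound 4 `OC(c1ccc(Cl)cc1)(c1cccnc1)c1ccccc1C(F)(F)F` has not yet been measured. It stands to compound 3 as compound 2 stands to compound 1: the change is trifluoromethyl in place of bromo on an aromatic carbon. The place is not identical, since here the group is ortho to a large group rather than para to a large group, so it is the same kind of change rather than the same change. The step from compound 3 to compound 4 in this assay is expected to be a 1.0-fold lower number from compound 3 to compound 4 (0.00 log units; within the scatter), an expectation that rests on the measured step of a 1.0-fold lower number from compound 1 to compound 2 (0.00 log units; within the scatter). Compound 4 is therefore estimated at 55000 nM, within a range from 35000 nM to 90000 nM.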

Compound 4, half-maximal inhibitory concentration: 59300 nM
Compound 4: the middle estimate sits 1.1-fold (0.03 log units) below what was measured; measured number inside the range.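

Trifluoromethyl in place of bromo, here ortho to a large group, gives in this assay a 1.1-fold higher number from compound 3 to compound 4 (0.03 log units; within the scatter). Set beside the same swap on the core of compound 1, the two results agree: the same change on two cores in this assay, a 1.0-fold lower number (0.00 log units; within the scatter) from compound 1 to compound 2 and a 1.1-fold higher number (0.03 log units; within the scatter) from compound 3 to compound 4, 1.1-fold (0.04 log units) apart, within the scatter of two such steps So in this cell test, the swap carried from one core to the other without any visible difference, but neither step rises above the scatter, so this is agreement between two steps with no visible size, and it cannot show that a larger effect would carry across the cores in the same way.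

The compounds shown leave open whether a different group in that place, such as an amine, a carboxylic acid or a longer chain, would shift the number beyond the scatter. They also leave open whether replacing the chloro group, which all four compounds keep, would do so.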